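Benzofuran sulfonamides: compound 3 to compound 4

The compounds below may be only part of what the source reports. "The series", "measured", "known", "first", "only" and "open" are said of these compounds alone.

Measured so far in a functional assay on HCT-116 cells (Homo sapiens) for inhibition, read by MTT assay, with a stated time of 72 h; a lower number here means a stronger inhibitor, a higher number a weaker inhibitor:
compound 1 `CCOC(=O)c1oc2ccc(NS(=O)(=O)c3ccc(Br)cc3)cc2c1C` gives > 40000 nM, a limit of the assay.
compound 2 `CCOC(=O)c1oc2ccc(NS(=O)(=O)c3ccc(C(F)(F)F)cc3)cc2c1C` gives 24200 nM.
compound 3 `CCOC(=O)c1oc2ccc(N(Cc3ccccc3)S(=O)(=O)c3cccc(Br)c3)cc2c1C` gives > 40000 nM, again a limit.

Compound 3 thus stands at the limit of > 40000 nM in this assay, at which 2 of the 3 values shown sit, and carries no number. Going by the values given here, the one measured step, an at least 1.6-fold lower number from compound 1 to compound 2 (0.21 log units; that floor lies within the scatter), concerns bromo to trifluoromethyl on the compound 1 core without the benzyl group, so it bears only loosely on the present change. Compound 4 `CCOC(=O)c1oc2ccc(N(Cc3ccccc3)S(=O)(=O)c3ccc(C)cc3)cc2c1C` differs from compound 3 by 4-methylphenyl in place of 3-bromophenyl on a sulfonyl sulfur. Among the compounds with values here, with no measured step covering this exchange, no shift beyond the scatter is expected; the estimated step is a number no higher from compound 3 to compound 4 (the limit leaves the size open). Compound 4 is expected to give 40000 nM in this assay, within 15000 nM to 100000 nM, most likely reported as a limit.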

Compound 4, half-maximal inhibitory concentration: > 40000 nM
Compound 4: a limit, no number; the forecaster's own chance of this, stated with the estimate: 70%; the middle value sits exactly at the limit.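

Compound 3 and compound 4 both stand at a limit, so no step between them can be read: the limit of > 40000 nM in this assay, at which 3 of the 4 values shown sit.

The compounds shown leave open whether 4-methylphenyl and 3-bromophenyl on a sulfonyl sulfur differ at all.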